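Removing the methylsulfanyl group from compound 2

The source may hold more compounds than are shown below. What is called first, only, known or untested is meant among the compounds shown, and "the series" means these compounds.

The measured compounds:
Compound 1, `C[Se]c1nc(N)c2ccccc2n1`, gives 23600 nM in an ADME assay on BEAS-2B cells (Homo sapiens) for cytotoxicity, read by MTT assay, with a stated time of 72 h; on this read-out higher numbers stand for weaker inhibition of growth and lower numbers for stronger inhibition of growth.
Compound 2, `CCCCC[Se]c1nc(NCc2ccc(SC)cc2)c2ccccc2n1`, gives 34700 nM in this assay.
Compound 3, `CSc1ccc(CNc2nc([SeH])nc3ccccc23)cc1`, gives 410 nM in this assay.

Compound 2 stands at the highest of the three numbers in this assay, though its gap to compound 1 is within the scatter; only compound 3 is set clearly apart from it, by an 85-fold lower number from compound 2 to compound 3 (1.93 log units; beyond the scatter).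

Compound 4, `CCCCC[Se]c1nc(NCc2ccccc2)c2ccccc2n1`, is made from compound 2 by hydrogen in place of methylsulfanyl on an aromatic carbon. For the measured compounds named here, no measured step touches this part of the molecule: the one large step, an 85-fold lower number from compound 2 to compound 3 (1.93 log units; beyond the scatter), concerns the group on the selenium, and compound 1 and compound 2 differ in several places at once. Going by the values given here, nothing among the measured compounds therefore points to a change beyond the scatter in this assay for this replacement. The number for compound 4 is expected to sit close to that of compound 2, with a 1.0-fold higher number from compound 2 to compound 4 (0.00 log units; within the scatter) as the estimated step. Compound 4 is thus estimated at 35000 nM, within a range from 12000 nM to 100000 nM.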

Compound 4, concentration for 50% growth inhibition: 44100 nM
The estimate for compound 4 lay 1.3-fold (0.10 log units) below the measured number, within the range that was stated.
By their numbers in this assay, from the lowest: compound 3; then compounds 1, 2 and 4 (each within the scatter of the next).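

In this assay the change from 4-(methylsulfanyl)phenyl to phenyl gives a 1.3-fold higher number from compound 2 to compound 4 (0.10 log units; within the scatter) and stays within the scatter, the first step among these compounds to read this place on the aromatic ring directly. For the compounds shown here, with pentyl on the selenium, the methylsulfanyl group para to a large group can therefore go without a change that can be told from the scatter, whereas the one large step, an 85-fold lower number from compound 2 to compound 3 (1.93 log units; beyond the scatter), lies at the selenium. Nothing available gives a measured reason for this result.

As far as these compounds go, whether a methoxy group, an amine or a carboxylic acid in this place would also stay within the scatter remains open. From the compounds shown here alone, it is also open whether removing methylsulfanyl would have so small a step with hydrogen on the selenium, as in compound 3.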